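Vero cytotoxicity notes: aryl ether variation, compounds 1 to 4

The source may hold more compounds than are shown below. What is called first, only, known or untested is meant among the compounds shown, and "the series" means these compounds.

compound 1 `CCc1nc2ccccc2n1CCCOc1ccccc1`: > 50 uM, a limit of the assay
compound 2 `CCc1nc2ccccc2n1CCCCOc1ccc(C)c(C)c1`: 14 uM
compound 3 `CCc1nc2ccccc2n1CCCCOc1ccccc1C(C)C`: 19 uM

Of the compounds shown here, three have been read in an ADME assay on Vero cells (Chlorocebus sabaeus) for cytotoxicity, read by luminescence, with a stated time of 2 days; on this read-out higher numbers stand for lower toxicity in this test and lower numbers for higher toxicity in this test. Compound 1 sits at the limit of > 50 uM in this assay, at which 1 of the 3 values shown sits, which is a limit of the assay and not a number. Compound 2 and compound 3 give numbers; of these two, compound 2 stands at the smaller one, and its gap to compound 3 lies within the scatter, so no order between the two is claimed. Among the measured compounds shown here, no pair of measured compounds differs in a single place, so the measured set offers no step to lean on.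

Compound 4 `CCc1nc2ccccc2n1CCCCOc1ccc(Cl)c(F)c1` is not yet measured. It differs from compound 2 by 4-chloro-3-fluorophenyl in place of 3,4-dimethylphenyl on an oxygen on a saturated carbon. With no measured step of this kind in the set, the expectation for this change is a step of no more than the scatter, in either direction, and a 1.2-fold lower number from compound 2 to compound 4 (0.07 log units; within the scatter) is the step the estimate below means. For compound 4 the estimated value in this assay is 12 uM, with a range from 5 uM to 30 uM.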

Compound 4, half-maximal toxic concentration: 16 uM
Compound 4: the middle estimate sits 1.3-fold (0.12 log units) below what was measured, within the range that was stated.
By their numbers in this assay, from the lowest: compounds 2, 4 and 3 (each within the scatter of the next). At a limit, above all of these: compound 1.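

The series now has its first single-place step in this assay: the exchange of 3,4-dimethylphenyl for 4-chloro-3-fluorophenyl on an oxygen on a saturated carbon gives a 1.1-fold higher number from compound 2 to compound 4 (0.06 log units; within the scatter). At this position, then, a ring bearing only carbon substituents and a ring bearing chlorine and fluorine read alike, with the heavy-atom count and the hydrogen-bond donor and acceptor counts unchanged by the exchange, so replacing both substituents at once leaves the read-out within the scatter. No measured property shown here bears on this step, and the result stands as an observation on this one pair only.

Still open is whether an aryl group carrying an amine or a carboxylic acid at this position would move the read-out beyond the scatter, as neither group stands among the compounds shown, and the single step says nothing about the chlorine and the fluorine taken one at a time. Also open is what a longer chain on the shared core would do with the aryl group held fixed, as no single-place step shown touches the chain.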